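A Cyclopropylamino Swap on the Carbonyl Carbon

The compounds below may be only part of what the source reports. "The series", "measured", "known", "first", "only" and "open" are said of these compounds alone.

Of the compounds shown here, two have so far been measured in a functional assay on the whole organism with Mus musculus as the target (on this read-out higher numbers stand for an effect only at larger amounts of compound and lower numbers for an effect already at smaller amounts), and they stand level. Compound 1 (`CCN(C)C(=O)/C=C1\CCc2c(F)cc(F)cc21`) gives 56 mg/kg and compound 2 (`CCNC(=O)/C=C1\CCc2ccc(F)cc21`) gives 70 mg/kg in that test, and these two values lie within the usual scatter of each other. The next compound to be tested is compound 3 (`O=C(/C=C1\CCc2c(F)cc(F)cc21)NC1CC1`), which keeps the core of compound 1 and carries cyclopropylamino in place of ethyl(methyl)amino on a carbonyl carbon. The entering group has a three-membered non-aromatic ring of carbon only and a hydrogen-bond donor. Among the measured compounds shown here, no measured pair differs in one place only, so the data give no direct size for this change. No shift beyond the scatter is therefore expected in this assay in either direction. This expectation rests only on compound 1 at 56 mg/kg and compound 2 at 70 mg/kg lying close together. The estimated step, a 1.1-fold higher number from compound 1 to compound 3 (0.03 log units; within the scatter), stays within the scatter. In this assay the estimated value for compound 3 is 60 mg/kg with an expected span from 25 mg/kg to 140 mg/kg as the likely range.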

Compound 3, dose for half-maximal effect: 62 mg/kg
Compound 3: middle estimate off by 1.0-fold (0.01 log units), on the low side, within the range that was stated.
By their numbers in this assay, from the lowest: compounds 1, 3 and 2 (each within the scatter of the next).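

Among the compounds shown here, the exchange of ethyl(methyl)amino for cyclopropylamino on a carbonyl carbon gives the first comparison at this position in which only one place differs, and in this assay it amounts to a 1.1-fold higher number from compound 1 to compound 3 (0.04 log units; within the scatter). With the core of compound 1 held fixed, this position accepts a group with a three-membered non-aromatic ring of carbon only and a hydrogen-bond donor in place of an open-chain group with no donor, and the read-out shows no shift beyond the scatter. No measurement at hand accounts for this level result.

From the compounds shown here alone, whether this position tolerates every group or only those of similar size remains open, as a single step of this kind cannot say how a longer chain such as hexylamino, a phenylamino group or a carboxylic acid on the same chain would read in this assay. Going by these compounds, it is also open whether cyclopropylamino would read the same way on the core of compound 2, and whether the unsubstituted amino group would hold the number level on either core.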